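Compound 4 Next to a Limit-Only Starting Point

A few compounds are considered here, and "the series" means these few. Any claim that something is new, unique, unknown or untested is made for them only; others in the source may bear on it.

Three compounds have been measured in an assay on HEK293 cells for positive allosteric modulation of metabotropic glutamate receptor 5 (Homo sapiens), read by FLIPR; a higher number here means that more compound is needed for the effect, a lower number that less compound is needed:

compound 1 `O=C(c1ccc(F)c(F)c1)N1CC(c2nc(-c3cccc(F)c3)no2)C1`: 3200 nM
compound 3 `O=C(c1ccc(Cl)cc1)N1CC(c2nc(-c3cccc(F)c3)no2)C1`: 2500 nM
compound 2 `COC1CCN(C(=O)N2CC(c3nc(-c4cccc(Cl)c4)no3)C2)CC1`: > 10000 nM

For compound 2 the value > 10000 nM is a limit of this assay, not a number, so compound 2 stands beyond the two compounds that gave numbers (the limit of > 10000 nM in this assay, at which 1 of the 3 values shown sits). Among the measured compounds shown here, the only measured step, a 1.3-fold lower number from compound 1 to compound 3 (0.11 log units; within the scatter), concerns a group on the carbonyl carbon in a different pair and lies within the scatter, so no measured step bears on the change to compound 4 `CC1CN(C(=O)N2CC(c3nc(-c4cccc(Cl)c4)no3)C2)CC(C)O1`. That change is 2,6-dimethylmorpholin-4-yl in place of 4-methoxypiperidin-1-yl on a carbonyl carbon. With only a limit as the starting point, compound 4 is expected to remain weak in this assay, estimated at 10000 nM (range 3000 nM to 30000 nM). The expected step is a number no higher from compound 2 to compound 4 (the limit leaves the size open).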

Compound 4, half-maximal effective concentration: > 10000 nM
Compound 4: a limit, no number; the forecaster's own chance of this, stated with the estimate: 60%; the middle value lies on the limit itself.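

Compound 2 and compound 4 each give only a limit in this assay, not a number, so no step between them can be read: the limit of > 10000 nM in this assay, at which 2 of the 4 values shown sit.

The compounds shown leave open whether 2,6-dimethylmorpholin-4-yl and 4-methoxypiperidin-1-yl on a carbonyl carbon differ at all in this assay.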